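Series notes: amine substituent swap on two sulfonamide cores

The source may hold more compounds than are shown below. What is called first, only, known or untested is meant among the compounds shown, and "the series" means these compounds.

Measured so far in a functional assay on A549 cells (Homo sapiens) for antiproliferative activity, read by sulforhodamine B assay, with a stated time of 72 h; on this read-out higher numbers stand for weaker inhibition and lower numbers for stronger inhibition:
compound 1 `COc1ncc(-c2ccc3ncnc(Nc4ccc(OCCO)cc4)c3c2)cc1NS(=O)(=O)c1ccc(F)cc1F` gives 2690 nM;
compound 2 `COc1ncc(-c2ccc3ncnc(Nc4cnn(CCCO)c4)c3c2)cc1NS(=O)(=O)c1ccc(F)cc1F` gives 4830 nM;
compound 3 `COc1ncc(-c2ccc3ncnc(Nc4cnn(CCCO)c4)c3c2)cc1NS(C)(=O)=O` gives 3600 nM.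

Compound 4 `COc1ncc(-c2ccc3ncnc(Nc4ccc(OCCO)cc4)c3c2)cc1NS(C)(=O)=O` is not yet measured in this assay. Compound 4 differs from compound 3 by 4-(2-hydroxyethoxy)phenyl in place of 1-(3-hydroxypropyl)-1H-pyrazol-4-yl on a nitrogen on an aromatic ring. The same change is made between two measured compounds, where compound 1 differs from compound 2 by 4-(2-hydroxyethoxy)phenyl in place of 1-(3-hydroxypropyl)-1H-pyrazol-4-yl on a nitrogen on an aromatic ring; the place lines of the two changes read the same word for word, so this is the same change. That change gave a 1.8-fold lower number from compound 2 to compound 1 (0.25 log units; within the scatter). The two cores differ by methyl in place of 2,4-difluorophenyl on a sulfonyl sulfur, a change that on its own gave a 1.3-fold lower number from compound 2 to compound 3 (0.13 log units; within the scatter). All three values sit within the scatter of one another, so no order among compounds 1, 2 and 3 is claimed.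

Among the compounds with values here, for compound 4 a step of a 1.8-fold lower number from compound 3 to compound 4 (0.26 log units; within the scatter) is expected, resting on the single earlier instance a 1.8-fold lower number from compound 2 to compound 1 (0.25 log units; within the scatter), which itself lay within the scatter. Compound 4 is estimated at 2000 nM, with a range from 900 nM to 4500 nM.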

Compound 4, half-maximal inhibitory concentration: 5200 nM
Compound 4: the middle estimate sits 2.6-fold (0.41 log units) below what was measured; measured number above the stated range.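

In this assay, the swap to 4-(2-hydroxyethoxy)phenyl on the core of compound 3 gives a 1.4-fold higher number from compound 3 to compound 4 (0.16 log units; within the scatter), and this step cannot be told apart from the earlier one: the same change on two cores in this assay, a 1.8-fold lower number (0.25 log units; within the scatter) from compound 2 to compound 1 and a 1.4-fold higher number (0.16 log units; within the scatter) from compound 3 to compound 4, 2.6-fold (0.41 log units) apart, within the scatter of two such steps

The swap of 2,4-difluorophenyl for methyl on a sulfonyl sulfur, read with the 4-(2-hydroxyethoxy)phenyl group in place, gives a 1.9-fold higher number from compound 1 to compound 4 (0.29 log units; within the scatter), and the comparison reads the same way: the same change on two cores in this assay, a 1.3-fold lower number (0.13 log units; within the scatter) from compound 2 to compound 3 and a 1.9-fold higher number (0.29 log units; within the scatter) from compound 1 to compound 4, 2.6-fold (0.41 log units) apart, within the scatter of two such steps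

Within the data shown here, the four compounds therefore give no sign that either change behaves differently from one core to the other, but they do not show that either change carries over, as no step or gap here lies beyond the scatter and neither change can be given a reliable size or sign.

Still open, from the compounds shown here alone, is whether any change at these two places moves the antiproliferative number beyond the scatter. A morpholine or a carboxylic acid in place of the hydroxyl on the amine substituent, or a longer alkyl chain on the sulfonyl sulfur, would be a further test of this.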